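The source may report more compounds than this note shows. Statements on the series, on what has been measured and on what is new or still open speak of the compounds shown alone.

Measured compounds in an assay on isolated protein for inhibition of Indoleamine 2,3-dioxygenase 2 (Homo sapiens); on this read-out higher numbers stand for weaker inhibition and lower numbers for stronger inhibition:
- compound 1 `OCCc1cn(CCNc2nonc2/C(=N/O)Nc2ccc(F)c(Br)c2)nn1` gives 1170 nM
- compound 2 `OCCCCc1cn(CCNc2nonc2/C(=N/O)Nc2ccc(F)c(Br)c2)nn1` gives 1080 nM
- compound 3 `CC(C)CC(C)(O)c1cn(CCNc2nonc2/C(=N/O)Nc2ccc(F)c(Br)c2)nn1` gives 689 nM

Compound 1 stands at the highest of the three numbers, but none of the three is separated from it beyond the scatter: a 1.1-fold lower number from compound 1 to compound 2 (0.03 log units; within the scatter) and a 1.7-fold lower number from compound 1 to compound 3 (0.23 log units; within the scatter). The step between the other two, a 1.6-fold lower number from compound 2 to compound 3 (0.20 log units; within the scatter), is likewise within the scatter. Across these three the substituent on the shared core changes from a straight hydroxyalkyl chain to a branched tertiary alcohol without a resolvable shift in this assay.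

Compound 4 `O/N=C(\Nc1ccc(F)c(Br)c1)c1nonc1NCCn1cc(C2(O)CCCCC2)nn1` is not yet measured. Relative to compound 1 the change is 1-hydroxycyclohexyl in place of 2-hydroxyethyl on an aromatic carbon. The closest measured analogue to this change is the move to compound 3, where a tertiary alcohol bearing branched carbons also replaces the 2-hydroxyethyl group; that step, a 1.7-fold lower number from compound 1 to compound 3 (0.23 log units; within the scatter), was within the scatter, as was a 1.6-fold lower number from compound 2 to compound 3 (0.20 log units; within the scatter). For the measured compounds named here, nothing so far shows a substituent on this aromatic carbon moving the number beyond the scatter. For compound 4 the expected step is therefore small, at most a slight move toward a lower number in line with compound 3, as a 1.5-fold lower number from compound 1 to compound 4 (0.18 log units; within the scatter). The estimate for compound 4 in this assay is 780 nM, with a range of 400 nM to 1500 nM.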

Compound 4, half-maximal inhibitory concentration: 865 nM
The estimate for compound 4 lay 1.1-fold (0.04 log units) below the measured number; measured number inside the range.
By their numbers in this assay, from the lowest: compounds 3, 4, 2 and 1 (each within the scatter of the next).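

In this assay, for the compounds shown here, 1-hydroxycyclohexyl brings a six-membered non-aromatic ring of carbon only onto this aromatic carbon for the first time, and the swap for 2-hydroxyethyl, 7 heavy atoms for 3, gives a 1.4-fold lower number from compound 1 to compound 4 (0.13 log units; within the scatter). The same group compared with the open-chain alcohols gives a 1.3-fold higher number from compound 3 to compound 4 (0.10 log units; within the scatter) and a 1.2-fold lower number from compound 2 to compound 4 (0.10 log units; within the scatter), so the ring-bearing tertiary alcohol cannot be told apart in this assay from either the branched tertiary alcohol or the straight hydroxyalkyl chains. The position therefore accepts this ring without any resolved shift, which extends the flat picture from open chains to a cyclic group, although no information here explains that flatness.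

Every group shown at this aromatic carbon carries a hydroxy group, so it remains open whether an amine, a carboxylic acid or a plain cyclohexyl with no hydroxy group would move the number beyond the scatter. Going by these compounds, an aromatic ring such as phenyl at this position, or a much longer chain, is equally untested by these compounds, and so the limits of what the position tolerates are still unknown.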